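Aryl-cap truncation in a homoserine lactone amide series

The source may report more compounds than this note shows. Statements on the series, on what has been measured and on what is new or still open speak of the compounds shown alone.

Measured compounds:
compound 1, `O=C(CCCCCc1ccccc1)CC(=O)N[C@H]1CCOC1=O`, 44000 nM
compound 2, `O=C(CCCCCCCCCCc1ccccc1)N[C@H]1CCOC1=O`, 70000 nM
compound 3, `O=C(CCCCCCCc1ccccc1)CC(=O)N[C@H]1CCOC1=O`, 42000 nM

The three compounds were measured in a functional assay on NCI-H630 cells (Homo sapiens) for cytotoxicity, read by sulforhodamine B assay, with a stated time of 5 days; a higher number here means a weaker inhibitor, a lower number a stronger inhibitor. All three numbers are close to one another. Compound 2 gives the highest of the three numbers, yet its gaps to compound 1 and to compound 3 are both within the scatter, so no order among the three can be stated.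

Compound 3 and compound 1 differ in one place: phenyl in place of phenethyl on a saturated chain carbon, five bonds along the chain from a carbonyl carbon. The step of a 1.0-fold higher number from compound 3 to compound 1 (0.02 log units; within the scatter) shows that this change left the number essentially unchanged.

Compound 4, `O=C(CCCCCCCCc1ccccc1)N[C@H]1CCOC1=O`, is not yet measured. It differs from compound 2 in one place: phenyl in place of phenethyl on a saturated chain carbon, eight bonds along the chain from a carbonyl carbon. This is the same kind of change as that from compound 3 to compound 1, but the place is not identical: in the measured pair the change sits five bonds along the chain from a carbonyl carbon, whereas from compound 2 to compound 4 it sits eight bonds along the chain from a carbonyl carbon. The difference between the core of compound 2 and the core of compound 3 is not broken down here.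

For compound 4 a step of about a 1.1-fold lower number from compound 2 to compound 4 (0.03 log units; within the scatter) is expected in this assay, resting on the flat step a 1.0-fold higher number from compound 3 to compound 1 (0.02 log units; within the scatter) seen for the same kind of change. Compound 4 is therefore estimated at 65000 nM, with a range from 32000 nM to 130000 nM.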

Compound 4, half-maximal inhibitory concentration: > 100000 nM
Compound 4 gave a limit, no number; the forecaster's own chance of this, stated with the estimate: 15%; at least 1.5-fold (0.18 log units) between middle value and limit.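

In this assay compound 4 gives > 100000 nM, which is a limit of the assay and not a number. Phenyl in place of phenethyl on a saturated chain carbon, eight bonds along the chain from a carbonyl carbon, gives an at least 1.4-fold higher number from compound 2 to compound 4 (0.15 log units; that floor lies within the scatter), so this step has a floor but no measured size, and the floor does not establish a real shift on this core. Whether the change carries from one core to the other with the same effect therefore stays undecided, and the data neither show that it transfers nor show that it depends on the core: the same change on two cores in this assay, a 1.0-fold higher number (0.02 log units; within the scatter) from compound 3 to compound 1 and an at least 1.4-fold higher number (0.15 log units; that floor lies within the scatter) from compound 2 to compound 4; the limit leaves it open whether they differ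

Going by these compounds, how far the true value of compound 4 lies past its limit remains open, and a further reading on this core would need a range that reaches past that limit: the limit of > 100000 nM in this assay, at which 1 of the 4 values shown sits. Also open is how a carboxylic acid or an amine in place of phenyl, or a longer chain on either core, would read in this assay.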